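Adding trifluoromethyl to compound 2

The source may report more compounds than this note shows. Statements on the series, on what has been measured and on what is new or still open speak of the compounds shown alone.

Measured so far in an ADME assay on MT4 cells (Homo sapiens) for cytotoxicity, read by MTT assay, with a stated time of 96 h; a lower number here means that less compound is tolerated, a higher number that more compound is tolerated:
compound 1 `c1ccc(/N=N/N2CCN(c3ccccc3)CC2)cc1`: 33000 nM
compound 2 `c1ccc(/N=N/c2ccc(NC[C@@H]3CCCN4CCCC[C@H]34)c3c2CCCC3)cc1`: 100000 nM

Of these two compounds, compound 2 stands higher at 100000 nM, so more of it is tolerated. The gap down to compound 1 at 33000 nM is beyond the usual scatter of repeated measurements.

Compound 3 `FC(F)(F)c1cccc(/N=N/c2ccc(NC[C@@H]3CCCN4CCCC[C@H]34)c3c2CCCC3)c1` differs from compound 2 in one place: trifluoromethyl in place of hydrogen on an aromatic carbon. Trifluoromethyl takes the place of hydrogen on an aromatic carbon, meta to a large group.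

The two measured compounds do not differ in one place only, so they offer no direct guide to this change. A moderate move toward a lower number in this assay is expected, though one within the scatter remains possible. The expected size of this move is a 2.0-fold lower number from compound 2 to compound 3 (0.30 log units; within the scatter). For compound 3 the estimate is 50000 nM, with an expected range of 15000 nM to 100000 nM.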

Compound 3, half-maximal cytotoxic concentration: 15000 nM
Beside the measured number, compound 3's estimate is 3.3-fold (0.52 log units) above it; the range from low to high includes it.
By their numbers in this assay, from the lowest: compound 3; then compound 1; then compound 2.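

In this assay there is now a step between compounds that differ in one place: exchanging phenyl for 3-(trifluoromethyl)phenyl gives a 6.7-fold lower number from compound 2 to compound 3 (0.82 log units; beyond the scatter) and so means that less compound is tolerated. This shows that the phenyl ring of compound 2 is not a neutral place in this assay, since a change on one of its aromatic carbons, meta to a large group, clearly shifts the reading. Nothing measured here accounts for the shift.

As far as these compounds go, it remains open whether this shift belongs to trifluoromethyl itself or would also follow from another group, such as a methyl, an amine or a carboxylic acid, on the same carbon. Also open, from the compounds shown here alone, is whether trifluoromethyl on a different carbon of that ring would move the number as far.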